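Working notes: cyclohexylcarbonyl replacing the carbamoyl group of compound 3

This account rests on a few compounds, and the source may have more. Where it says the series, first, only, none or still open, it means among the compounds named here.

compound 1 `COc1ncc(NC(=O)[C@H](C)[C@H]2CC[C@@H](c3ccnc4ccc(F)cc43)CC2)cn1`: in an assay on tissue (HeLa cells) for inhibition of Indoleamine 2,3-dioxygenase 1 (Homo sapiens), with stated times of 2 h and 18 h (a higher number here means a weaker inhibitor, a lower number a stronger inhibitor), compound 1 gives 10 nM
compound 2 `C[C@@H](c1nc2ccc(Cl)cc2[nH]1)[C@H]1CC[C@@H](c2ccnc3ccc(F)cc32)CC1`: in this assay compound 2 gives 4 nM
compound 3 `C[C@@H](NC(=O)Nc1ccc(Cl)cc1)[C@H]1CC[C@@H](c2ccnc3ccc(F)cc32)CC1`: in this assay compound 3 gives 20 nM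

Compound 3 carries the highest number of the three in this assay. Its nearest neighbour is compound 1, and that gap lies within the scatter, so no order between compound 3 and compound 1 is claimed. The gap to compound 2 lies beyond the scatter, so compound 3 is the weaker of those two.

Compound 4 `C[C@@H](NC(=O)C1CCCCC1)[C@H]1CC[C@@H](c2ccnc3ccc(F)cc32)CC1` differs from compound 3 by cyclohexyl in place of (4-chlorophenyl)amino on a carbonyl carbon. Going by the values given here, no pair of measured compounds isolates this change, and compound 1, though it also bears a carbonyl on the shared core, differs in more than one place and cannot stand in for it. Among the compounds with values here, with no prior step to lean on, the expectation for this assay is a step of a 1.5-fold higher number from compound 3 to compound 4 (0.18 log units; within the scatter) leaning towards a higher number but not clearly beyond the scatter. For compound 4 the estimate in this assay is 30 nM, with a range from 8 nM to 120 nM.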

Compound 4, half-maximal inhibitory concentration: 12 nM
Compound 4: middle estimate off by 2.5-fold (0.40 log units), on the high side; low and high end bracket the measured number.
By their numbers in this assay, from the lowest: compound 2; then compounds 1, 4 and 3 (each within the scatter of the next).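

In this assay, going by these compounds alone, the one matched step at this carbonyl carbon is a 1.7-fold lower number from compound 3 to compound 4 (0.22 log units; within the scatter), with cyclohexyl in place of (4-chlorophenyl)amino. The aromatic ring, the chlorine, the nitrogen and its hydrogen-bond donor all leave together without a step beyond the scatter, so none of them is shown to be required at this place on the shared core. No measurement at hand accounts for the size of this step.

Within the data shown here, the single step changes these features together, so what each contributes alone remains unresolved. Also open, on these data alone, is whether an amine, a carboxylic acid or a longer chain on this carbonyl carbon would keep the number within the scatter of compound 4 or move it beyond.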